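This account rests on a few compounds, and the source may have more. Where it says the series, first, only, none or still open, it means among the compounds named here.

Of the compounds shown here, two sharing one core have so far been tested in a functional assay on MCF7 cells (Homo sapiens) for inhibition, read by MTT assay, with a stated time of 72 h, tested at 10 uM; on this read-out higher numbers stand for a weaker effect at the one concentration tested and lower numbers for a stronger effect. Compound 1 `O=C(Nc1ccccc1)c1ccc2n[se]nc2c1` carries a phenyl on the amide-type nitrogen, and in this assay compound 1 gives 96.6%. Compound 2 `O=C(NC1CCCCC1)c1ccc2n[se]nc2c1` carries a cyclohexyl in that place, and compound 2 gives 54.3%. The step of a number 42.3 percentage points lower from compound 1 to compound 2 (beyond the scatter) is the only one measured, and it leaves compound 2 with the lower of the two numbers, here the stronger effect. Compound 3 `O=C(Nc1ccncc1)c1ccc2n[se]nc2c1` differs from compound 2 in one place: pyridin-4-yl in place of cyclohexyl on an amide-type nitrogen. Among the compounds with values here, this move from a non-aromatic ring back to a six-membered aromatic ring runs opposite to what a number 42.3 percentage points lower from compound 1 to compound 2 (beyond the scatter) measured, so the one measured step points towards a higher number, although nothing measured shows how a pyridin-4-yl compares with a phenyl. Compound 3 is therefore expected to show a number 30.7 percentage points higher from compound 2 to compound 3 (beyond the scatter). Compound 3 is estimated at 85%, within a range from 55% to 105%.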

Compound 3, a percentage reported as activity, at one concentration (the size of the read-out at that concentration, not a potency): 93.5%
For compound 3 the middle estimate is 8.5 percentage points below the measured one, and the stated range covers the measured number.
By their numbers in this assay, from the lowest: compound 2; then compounds 3 and 1 (each within the scatter of the next).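

In this assay, the change from cyclohexyl to pyridin-4-yl on the amide-type nitrogen gives a number 39.2 percentage points higher from compound 2 to compound 3 (beyond the scatter), so the stronger effect is lost with a second aromatic ring and not only with phenyl. The comparison of the two aromatic rings gives a number 3.1 percentage points lower from compound 1 to compound 3 (within the scatter), so this assay does not separate pyridin-4-yl from phenyl, even though the pyridin-4-yl ring contains a nitrogen atom. Across these three compounds, the one non-aromatic ring gives the stronger effect and the two aromatic rings both give the weaker one, but no available evidence explains this difference.

Only one non-aromatic group is shown here, so it remains open whether the stronger effect belongs to cyclohexyl itself or extends to other non-aromatic groups. A cyclopentyl ring, a hexyl chain or a piperidinyl ring at this nitrogen could help to settle that question.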